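The source may hold more compounds than are shown below. What is called first, only, known or untested is meant among the compounds shown, and "the series" means these compounds.

Measured so far:
- compound 1 `O=C(Nc1ncc(Cc2ccccn2)s1)C1CCCCC1` | > 40000 nM
- compound 2 `O=C(Nc1ncc(Cc2csc3ccccc23)s1)C1CCCCC1` | "not determined" (no result reported)

In an ADME assay on P388D1 cells (Mus musculus) for cytotoxicity, read by fluorescence and resazurin assay, with a stated time of 72 h (a higher number here means a weaker inhibitor, a lower number a stronger inhibitor), compound 1 gives > 40000 nM and this is a limit of the assay, not a number. For compound 2 the entry reads "not determined" (no result reported) so it offers no comparison. For the measured compounds named here, compound 1 therefore has no exact position on the scale, and the series has no measured step to use as a guide.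

The next compound is compound 3 `O=C(Nc1ncc(CC2CCCC2)s1)C1CCCCC1` with cyclopentyl in place of pyridin-2-yl on a saturated chain carbon bound to an aromatic carbon. The rest of the structure is the same as in compound 1.

Going by the values given here, with no measured step available, only a small change in this assay is expected, if any, leaning towards a stronger inhibitor. The expected step is an at least 1.3-fold lower number from compound 1 to compound 3 (0.12 log units; that floor lies within the scatter) and the assay may well report only a limit again. For compound 3 the estimated value is 30000 nM with an expected range from 10000 nM to 60000 nM.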

Compound 3, half-maximal inhibitory concentration: > 40000 nM
Compound 3: only a limit was reported; the forecaster's own chance of this, stated with the estimate: 55%; middle value at least 1.3-fold (0.12 log units) away from the limit.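

In this assay compound 3 gives > 40000 nM, which is a limit and not a number. Compound 1 also carries only a limit, so no step can be read between compound 1 and compound 3: the limit of > 40000 nM in this assay, at which 2 of the 3 values shown sit.

The compounds shown leave open where either compound lies on the scale and whether cyclopentyl in place of pyridin-2-yl changes the read-out at all.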